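Compound 2 to compound 3: a seven-membered ring enters

A few compounds are considered here, and "the series" means these few. Any claim that something is new, unique, unknown or untested is made for them only; others in the source may bear on it.

Within the data shown here, in an ADME assay on microsomes from liver (Homo sapiens) for metabolic stability (on this read-out lower numbers stand for slow clearance and higher numbers for fast clearance), compound 2 (`CC(=O)N[C@@H]1CCC[C@H](C(=O)Nc2cc(-c3cnc4n3CCC4)c(Cl)cn2)C1`) gives 9.7 mL.min-1.g-1 as the only actual number so far. Compound 1 (`CC(=O)N[C@@H]1CCC[C@H](C(=O)Nc2cc(-c3cnn4c3CCC4)c(Cl)cn2)C1`) gives < 3 mL.min-1.g-1 as a limit of the assay and not a number. Compound 3 (`CC(=O)N[C@@H]1CCC[C@H](C(=O)Nc2cc(-c3cnn4c3CCCCC4)c(Cl)cn2)C1`) differs from compound 2 by a group of 10 heavy atoms (8 carbon, 2 nitrogen; one five-membered aromatic ring with 2 hetero atoms, one seven-membered non-aromatic ring with 1 hetero atom) in place of a group of 8 heavy atoms (6 carbon, 2 nitrogen; one five-membered non-aromatic ring with 1 hetero atom, one five-membered aromatic ring with 2 hetero atoms), on an aromatic carbon at the same place, ortho to a chloro group. Among the measured compounds shown here, the single measured step (an at least 3.2-fold higher number from compound 1 to compound 2 (0.50 log units; beyond the scatter)) exchanges one group for another on that aromatic carbon, so this place can shift the read-out, but that step gives no direction for a larger group. The estimated step is a 1.1-fold lower number from compound 2 to compound 3 (0.03 log units; within the scatter) and nothing beyond the scatter is expected. In this assay compound 3 is expected at 9 mL.min-1.g-1 and estimated to fall from 3.5 mL.min-1.g-1 to 25 mL.min-1.g-1 on repeat measurement.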

Compound 3, intrinsic clearance in microsomes in the Homo sapiens assay: 39 mL.min-1.g-1
For compound 3 the middle estimate is 4.3-fold (0.64 log units) below the measured one; the whole stated range lies below it.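

In the Homo sapiens assay the larger ring gives this aromatic carbon a direction that the earlier step could not: a 4.0-fold higher number from compound 2 to compound 3 (0.60 log units; beyond the scatter), and an at least 13-fold higher number from compound 1 to compound 3 (1.11 log units; beyond the scatter). In the Homo sapiens assay compound 1 stands at < 3 mL.min-1.g-1, which is a limit of the assay and not a number. The same change also gives a lower number in a physicochemical assay for solubility, in phosphate buffer, at pH 7.4; a lower number here means a less soluble compound, a higher number a more soluble compound: the measured solubility of compound 2, 490000 nM, and of compound 3, 104000 nM, a 4.7-fold lower number (0.67 log units; beyond the scatter). In the physicochemical assay compound 2 gives 490000 nM and compound 3 gives 104000 nM.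

The compounds shown leave open how a six-membered non-aromatic ring would read at this place in the Homo sapiens assay, and whether a hydroxyl group on the seven-membered ring would change either read-out.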